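Aryl for Alkyl on the Chain at the Ring Nitrogen

The compounds below may be only part of what the source reports. "The series", "measured", "known", "first", "only" and "open" are said of these compounds alone.

Compound 1 `C[C@@H]1CN(Cc2ccccc2)c2ncccc2[C@H](C)N1C(=O)NCc1ccccc1` gives 15 nM. Compound 2 `C[C@@H]1CN(Cc2ccccc2)c2ccncc2[C@H](C)N1C(=O)NCc1ccccc1` gives 6280 nM. Compound 3 `COc1ccc(CNC(=O)N2[C@H](C)CN(CCC(C)C)c3cnccc3[C@@H]2C)cc1` gives 76 nM.

All three were measured in an assay on HEK293 cells for inhibition of Voltage-dependent T-type calcium channel subunit alpha-1G (Homo sapiens), read by FLIPR and calcium flux, with a stated time of 3 min; on this read-out higher numbers stand for weaker inhibition and lower numbers for stronger inhibition. Compound 3 stands second highest of the three numbers; compound 1 sits nearest with a lower number, compound 2 furthest with a higher one, and both separations lie beyond the usual scatter. For the measured compounds named here, no measured pair isolates a single change, so these values show only the spread across differing cores and substituents.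

Compound 4 `COc1ccc(CNC(=O)N2[C@H](C)CN(Cc3ccc(C(F)(F)F)o3)c3cnccc3[C@@H]2C)cc1` differs from compound 3 as follows: 5-(trifluoromethyl)furan-2-yl in place of isobutyl on a saturated chain carbon bound to a nitrogen on an aromatic ring in a ring. The expected step is a 1.9-fold lower number from compound 3 to compound 4 (0.28 log units; within the scatter), a modest move toward a lower number that may not clear the scatter. Compound 4 is estimated at 40 nM, within 10 nM to 160 nM.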

Compound 4, half-maximal inhibitory concentration: 13 nM
Compound 4: the middle estimate sits 3.1-fold (0.49 log units) above what was measured; the measured number falls inside the stated range.
By their numbers in this assay, from the lowest: compounds 4 and 1 (each within the scatter of the next); then compound 3; then compound 2.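

For the compounds shown here, this is the first comparison in the set that isolates one change: on the saturated chain carbon bound to a nitrogen on an aromatic ring in a ring, 5-(trifluoromethyl)furan-2-yl in place of isobutyl gives a 5.8-fold lower number from compound 3 to compound 4 (0.77 log units; beyond the scatter), a step beyond the scatter. The position thus accepts a larger group carrying an aromatic ring, and inhibition grows stronger. Nothing at hand explains this step.

From the compounds shown here alone, whether the step comes from the furan ring or from its trifluoromethyl stays open. So does how an unsubstituted furan, a phenyl ring or a longer chain would read at this place.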